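Swapping a Ring Oxygen for a Hindered Amine

The source may hold more compounds than are shown below. What is called first, only, known or untested is meant among the compounds shown, and "the series" means these compounds.

Three compounds have a measured result in an assay for inhibition of serine/threonine-protein kinase Sgk1 (Homo sapiens), with stated times of 30 min and 60 min, in the presence of a further agent that is not named here; a lower number here means a stronger inhibitor, a higher number a weaker inhibitor. Compound 1 `O=C(NC1CCN(C2CC2)C1)c1cc(-c2ccc(NS(=O)(=O)c3cccc(Cl)c3Cl)cc2)nc2[nH]ncc12` gives 610 nM. Compound 2 `Cc1n[nH]c2nc(-c3ccc(NS(=O)(=O)c4cc(Cl)ccc4F)cc3)nc(OCCC(=O)N(C)C)c12` gives 438 nM, and compound 3 `Cc1n[nH]c2nc(-c3ccc(NS(=O)(=O)c4cc(Cl)ccc4F)cc3)nc(OC3CCOCC3)c12` gives 14 nM, the lowest of the three numbers; its nearest neighbour is compound 2 and its furthest compound 1, and both gaps lie beyond the usual scatter. For the measured compounds named here, the only single-point step measured here runs a 31-fold lower number from compound 2 to compound 3 (1.50 log units; beyond the scatter), a large change that turned on the group carried by the oxygen on the aromatic ring.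

Compound 4 `Cc1n[nH]c2nc(-c3ccc(NS(=O)(=O)c4cc(Cl)ccc4F)cc3)nc(OC3CC(C)(C)NC(C)(C)C3)c12` is not yet measured. It alters that same group: 2,2,6,6-tetramethylpiperidin-4-yl in place of oxan-4-yl on an oxygen on an aromatic ring. Going by the values given here, the step from compound 2 to compound 3 shows that this position can move the number strongly, but it compared a chain against a ring, whereas here one six-membered ring replaces another, and no measured pair tells how the 2,2,6,6-tetramethylpiperidin-4-yl group will be received. The expectation is therefore cautious. For compound 4 the expected step is a 1.4-fold higher number from compound 3 to compound 4 (0.15 log units; within the scatter), which may not exceed the scatter. Compound 4 is expected to give about 20 nM in this assay, with a likely range from 5 nM to 80 nM.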

Compound 4, half-maximal inhibitory concentration: 4 nM
Beside the measured number, compound 4's estimate is 5.0-fold (0.70 log units) above it, and the stated range ends above it.
By their numbers in this assay, from the lowest: compound 4; then compound 3; then compounds 2 and 1 (each within the scatter of the next).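

For the compounds shown here, the earlier compounds showed only that a ring on this oxygen could differ sharply from a chain, and the new result shows that the choice of ring matters too: in this assay, the swap of one six-membered ring for another gives a 3.5-fold lower number from compound 3 to compound 4 (0.54 log units; beyond the scatter). This position therefore accepts the larger 2,2,6,6-tetramethylpiperidin-4-yl group without any loss, and the number falls further, so the oxygen in the oxan-4-yl ring is not needed to keep it low. Across the groups carried by this oxygen, the widest measured change is now a 110-fold lower number from compound 2 to compound 4 (2.04 log units; beyond the scatter), which makes this one place on the molecule a strong lever on the number. No measurement here explains why the tetramethylpiperidine ring gives the lower number.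

The change brings in a ring nitrogen with its hydrogen and the methyl groups together, so the compounds shown leave open which of these goes with the lower number; a plain piperidin-4-yl group, without the methyl groups, or a cyclohexyl ring, without the nitrogen, would begin to separate them. They also leave open whether an amine needs to sit in a ring at all, a question that an open chain such as 2-(dimethylamino)ethyl could address.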